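The compounds below may be only part of what the source reports. "The series", "measured", "known", "first", "only" and "open" are said of these compounds alone.

Three compounds share one core and differ only in the length of the saturated chain attached to the carbonyl. In a functional assay on SW1573 cells (Homo sapiens) for cytotoxicity, read by sulforhodamine B assay, with a stated time of 72 h (a higher number here means a weaker inhibitor, a lower number a stronger inhibitor), compound 1 `CCCCCCC(=O)Nc1ccn([C@@H]2CO[C@H](CO)O2)c(=O)n1` gives 2400 nM, compound 2 `CCCCCCCCCC(=O)Nc1ccn([C@@H]2CO[C@H](CO)O2)c(=O)n1` gives 40 nM, and compound 3 `CCCCCCCCCCCC(=O)Nc1ccn([C@@H]2CO[C@H](CO)O2)c(=O)n1` gives 30 nM. Compound 3 has the lowest number of the three, but its gap to compound 2 lies within the scatter, while the step of an 80-fold lower number from compound 1 to compound 3 (1.90 log units; beyond the scatter) is large. Compound 4 `CCCCCCCCCCCCCCCCCC(=O)Nc1ccn([C@@H]2CO[C@H](CO)O2)c(=O)n1` carries hexyl in place of hydrogen on a saturated chain carbon, ten or more bonds along the chain from a carbonyl carbon. Among the measured steps, a 60-fold lower number from compound 1 to compound 2 (1.78 log units; beyond the scatter) and an 80-fold lower number from compound 1 to compound 3 (1.90 log units; beyond the scatter) were large, yet a 1.3-fold lower number from compound 2 to compound 3 (0.12 log units; within the scatter) stayed within the scatter, so still longer chains are expected to change little. Compound 4 is therefore estimated at 35 nM, between 10 nM and 150 nM, an expected step of a 1.2-fold higher number from compound 3 to compound 4 (0.07 log units; within the scatter) in this assay.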

Compound 4, half-maximal inhibitory concentration: 125 nM
For compound 4 the middle estimate is 3.6-fold (0.55 log units) below the measured one; measured number inside the range.
By their numbers in this assay, from the lowest: compounds 3 and 2 (each within the scatter of the next); then compound 4; then compound 1.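

Hexyl in place of hydrogen at this far point of the chain does not leave the number level: in this assay there is a 4.2-fold higher number from compound 3 to compound 4 (0.62 log units; beyond the scatter), and likewise a 3.1-fold higher number from compound 2 to compound 4 (0.49 log units; beyond the scatter). The gain from lengthening the chain therefore does not simply persist, and compound 4 is the one that goes against any steady trend. Even so, much of the gain remains, with a 19-fold lower number from compound 1 to compound 4 (1.28 log units; beyond the scatter). Nothing available here explains the rise. Going by these compounds, how a still longer chain, or an amine or carboxylic acid in place of the hexyl, would read remains open.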